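Toward a carboxylic acid on the amide of compound 1

The compounds below may be only part of what the source reports. "The series", "measured", "known", "first", "only" and "open" are said of these compounds alone.

Compound 1 `CCN(CC)CCCNC(=O)c1ccc(C(CC)(CC)c2ccc(C#CC(O)(CC)CC)c(C)c2)n1CC` gives 68.9 nM in an assay on cells for agonist activity at vitamin D3 receptor (Homo sapiens), read by microscopy; on this read-out higher numbers stand for an effect only at larger amounts of compound and lower numbers for an effect already at smaller amounts.
Compound 2 `CCn1c(C(=O)NCc2ccc(OC)cc2)ccc1C(CC)(CC)c1ccc(C#CC(O)(CC)CC)c(C)c1` in this assay gives > 50 nM, which is a limit of the assay and not a number.
Compound 3 `CCCCC(=O)c1ccc(C(CC)(CC)c2ccc(C#CC(O)(CC)CC)c(C)c2)n1CC` in this assay gives > 50 nM, likewise a limit and not a number.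

Compound 1 thus holds the only number shown; the other two values are limits. Compound 4 `CCn1c(C(=O)N[C@H](C(=O)O)C(C)C)ccc1C(CC)(CC)c1ccc(C#CC(O)(CC)CC)c(C)c1` differs from compound 1 by 1-carboxy-2-methylpropyl in place of 3-(diethylamino)propyl on an amide-type nitrogen. The measured steps from compound 1 each alter the same amide tail: a step that the limit leaves unreadable from compound 1 to compound 2 and a step that the limit leaves unreadable from compound 1 to compound 3, neither readable in size because of the limit of > 50 nM in this assay, at which 2 of the 3 values shown sit. Both changes left the tail without its amine and reached the limit; the change to compound 4 likewise removes that amine. For compound 4 a step of a 2.6-fold higher number from compound 1 to compound 4 (0.42 log units; beyond the scatter) in this assay is therefore expected, pointing to weaker potency. The estimate for compound 4 is 180 nM, within 45 nM to 700 nM.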

Compound 4, half-maximal effective concentration: 17.7 nM
Compound 4: middle estimate off by 10-fold (1.01 log units), on the high side; measured number below the stated range.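

Compound 4 shows that this tail on the amide-type nitrogen can lose its amine without any loss in this assay: the change to 1-carboxy-2-methylpropyl brings a 3.9-fold lower number from compound 1 to compound 4 (0.59 log units; beyond the scatter). Against the other two tails it gives an at least 2.8-fold lower number from compound 2 to compound 4 (0.45 log units; beyond the scatter) and an at least 2.8-fold lower number from compound 3 to compound 4 (0.45 log units; beyond the scatter). Those two steps start from limits and not from numbers: the limit of > 50 nM in this assay, at which 2 of the 4 values shown sit.

Whether the carboxylic acid or the branched chain of compound 4 accounts for the step stays open. So does the part of its defined stereocentre, and how a methyl ester or a shorter acid such as carboxymethyl would read at this nitrogen.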